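Bromo to Nitrooxy: Carrying a Small Step Across Cores

The compounds below may be only part of what the source reports. "The series", "measured", "known", "first", "only" and "open" are said of these compounds alone.

Compound 1 `O=C(CBr)Nc1ccc(C(=O)/C=C/c2ccco2)cc1` and compound 2 `O=C(CO[N+](=O)[O-])Nc1ccc(C(=O)/C=C/c2ccco2)cc1` share one core and differ in a single place: nitrooxy in place of bromo on a saturated chain carbon bound to a carbonyl carbon In a functional assay on the whole organism (strain albino) for inhibition, with Rattus norvegicus as the target, read by paw edema, with stated times of 30 min and 4 h, at a dose of 100 mg/kg by the oral route (a lower number here means less inhibition, a higher number more inhibition at the dose given (going by the name of the read-out)), compound 1 gives 33% and compound 2 gives 40%, so the change made a number 7 percentage points higher from compound 1 to compound 2 (within the scatter). Compound 3 `CC(Br)C(=O)Nc1ccc(C(=O)/C=C/c2ccc(Cl)cc2)cc1` rests on another core; how its core differs from that of compound 1 is not broken down here. In this assay compound 3 gives 54%, the highest of the three. Compound 4 `CC(O[N+](=O)[O-])C(=O)Nc1ccc(C(=O)/C=C/c2ccc(Cl)cc2)cc1` is not yet measured and stands apart from compound 3 by the same kind of change: nitrooxy in place of bromo on a saturated chain carbon bound to a carbonyl carbon and a saturated chain carbon The place is not identical, since here the carbon is bound to a carbonyl carbon and a saturated chain carbon rather than to a carbonyl carbon alone. The step from compound 3 to compound 4 is expected to be a number 5 percentage points higher from compound 3 to compound 4 (within the scatter), resting on the earlier step of a number 7 percentage points higher from compound 1 to compound 2 (within the scatter). In this assay compound 4 is estimated at 59%, between 46% and 72%.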

Compound 4, a percentage reported as inhibition, in the whole organism at one dose (the size of the read-out at that dose, not a potency): 61%
For compound 4 the middle estimate is 2 percentage points below the measured one; measured number inside the range.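

On the core of compound 3, the swap of bromo for nitrooxy gave a number 7 percentage points higher from compound 3 to compound 4 (within the scatter), and this matches the earlier step on the core of compound 1: the same change on two cores in this assay, a number 7 percentage points higher (within the scatter) from compound 1 to compound 2 and a number 7 percentage points higher (within the scatter) from compound 3 to compound 4, 0 percentage points apart, within the scatter of two such steps. In this assay, then, the change carried over from one core to the other with much the same size. Each step on its own lies within the scatter, however, so neither shows that nitrooxy truly gives more inhibition than bromo, and two cores cannot speak for the whole series.

The compounds shown leave open how other groups would fare in the same place, such as an amine, a carboxylic acid or a longer chain ending in nitrooxy. They also leave open whether the swap would behave alike on a further core.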